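The source may hold more compounds than are shown below. What is called first, only, known or untested is meant among the compounds shown, and "the series" means these compounds.

Three compounds have been measured in a functional assay on cells (Homo sapiens) for antiproliferative activity, read by MTT assay, with a stated time of 48 h; on this read-out lower numbers stand for stronger inhibition and higher numbers for weaker inhibition:

Compound 1 `CN(C)CCCn1c(N)c(-c2nc3ccccc3[nH]2)c2nc(C#N)c(C#N)nc21`: 1820 nM
Compound 2 `CCN(CC)CCCn1c(N)c(-c2nc3ccccc3[nH]2)c2nc(C#N)c(C#N)nc21`: 28900 nM
Compound 3 `CN(C)CCCCn1c(N)c(-c2nc3ccccc3o2)c2nc(C#N)c(C#N)nc21`: 6130 nM

From compound 1 to compound 2 the change is diethylamino in place of dimethylamino on a saturated chain carbon, three bonds along the chain from an aromatic nitrogen, and it produced a 16-fold higher number from compound 1 to compound 2 (1.20 log units; beyond the scatter). Compound 4 `CCN(CC)CCCCn1c(N)c(-c2nc3ccccc3o2)c2nc(C#N)c(C#N)nc21` is not yet measured; it relates to compound 3 by diethylamino in place of dimethylamino on a saturated chain carbon, four bonds along the chain from an aromatic nitrogen. The place is not identical: in compound 4 the saturated chain carbon is four bonds along the chain from an aromatic nitrogen rather than three, so this is the same kind of change, not the same one. The difference between the core of compound 1 and the core of compound 3 is not broken down here. In this assay compound 3 gives a number lying between those of compound 1 and compound 2.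

Because a 16-fold higher number from compound 1 to compound 2 (1.20 log units; beyond the scatter) is large, compound 4 is expected to show a 7.3-fold higher number from compound 3 to compound 4 (0.87 log units; beyond the scatter), taken somewhat smaller as the core and the place differ. Compound 4 is estimated at 45000 nM, with a range from 12000 nM to 180000 nM.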

Compound 4, half-maximal inhibitory concentration: 2710 nM
Beside the measured number, compound 4's estimate is 17-fold (1.22 log units) above it, outside the stated range (below it).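

In this assay the change from dimethylamino to diethylamino gave a 2.3-fold lower number from compound 3 to compound 4 (0.35 log units; beyond the scatter), a direction opposite to the one it took on the core of compound 1. Set side by side, the two steps differ: the same change on two cores in this assay, a 16-fold higher number (1.20 log units; beyond the scatter) from compound 1 to compound 2 and a 2.3-fold lower number (0.35 log units; beyond the scatter) from compound 3 to compound 4, 36-fold (1.56 log units) apart, beyond the scatter of two such steps This shows that the effect of the change could not be carried from one of these cores to the other, but it does not show what sets it, as the two pairs differ both in the core and in the place of the amine along the chain.

Among the compounds shown, no pair separates the core from the chain length, so which of the two governs the reversal stays open. Going by these compounds, how a piperidine or a morpholine at the chain end would behave on either core also remains open.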